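Adding fluoro to a compound sitting at the limit

The compounds below may be only part of what the source reports. "The series", "measured", "known", "first", "only" and "open" are said of these compounds alone.

- compound 1 `[N-]=[N+]=Nc1cc(=O)[nH]c(=O)n1[C@@H]1O[C@H](CO)[C@@H](O)[C@H]1O`: > 50000 nM
- compound 2 `Nc1cc(=O)[nH]c(=O)n1[C@@H]1O[C@H](CO)[C@@H](O)[C@H]1O`: > 50000 nM
- compound 3 `CN(C)c1cc(=O)[nH]c(=O)n1[C@@H]1O[C@H](CO)[C@@H](O)[C@H]1O`: > 50000 nM

In a functional assay on OCI-Ly7 cells (Homo sapiens) for antiproliferative activity, read by WST assay, with a stated time of 3 days (on this read-out higher numbers stand for weaker inhibition and lower numbers for stronger inhibition), compound 1 gives > 50000 nM, which is a limit and not a number. The other two values are limits as well, and all three sit at the same one: the limit of > 50000 nM in this assay, at which 3 of the 3 values shown sit.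

Compound 4 `[N-]=[N+]=Nc1c(F)c(=O)[nH]c(=O)n1[C@@H]1O[C@H](CO)[C@@H](O)[C@H]1O` has fluoro in place of hydrogen on an aromatic carbon, ortho to an azido group (fluoro in place of hydrogen on an aromatic carbon).

The measured steps are a step that the two limits leave unreadable from compound 1 to compound 2, a step that the two limits leave unreadable from compound 1 to compound 3 and a step that the two limits leave unreadable from compound 2 to compound 3. None of them gives a size, and none of them adds fluoro. Any shift towards stronger inhibition is therefore only a tentative expectation, and another limit is quite possible. The estimated change is an at least 1.6-fold lower number from compound 1 to compound 4 (0.22 log units; that floor lies within the scatter). Compound 4 is expected near 30000 nM, with an estimated range of 3000 nM to 50000 nM.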

Compound 4, half-maximal inhibitory concentration: 700 nM
Beside the measured number, compound 4's estimate is 43-fold (1.63 log units) above it; measured number outside the range, below it.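

In this assay, fluoro in place of hydrogen on the aromatic carbon ortho to an azido group gives an at least 71-fold lower number from compound 1 to compound 4 (1.85 log units; beyond the scatter). Going by these compounds alone, the earlier steps among compound 1, compound 2 and compound 3 cannot be read, so this is the first change with a readable size, and it shows that this carbon can matter greatly in the assay. Compound 4 is the only compound shown that has a value off the limit: the limit of > 50000 nM in this assay, at which 3 of the 4 values shown sit.

Going by these compounds, what chloro or methyl on this same carbon would give stays open. So does whether fluoro has a similar effect with amino in place of the azido group.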